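The source may hold more compounds than are shown below. What is called first, only, known or untested is meant among the compounds shown, and "the series" means these compounds.

Measured in an ADME assay on microsomes from liver (Rattus norvegicus) for metabolic stability; on this read-out higher numbers stand for a longer-lived compound and lower numbers for a shorter-lived compound:
- compound 1 `CS(=O)(=O)N1CCN(CC(O)CN2CCC(CNC(=O)c3cccc4[nH]c(C5CC5)nc34)CC2)CC1`: > 1.5 h (a limit)
- compound 2 `CC(C)(C)c1nc2c(C(=O)NCC3CCN(CC(O)CN4CCN(S(C)(=O)=O)CC4)CC3)cccc2[nH]1`: > 1.5 h (a limit)
- compound 3 `CC(C)c1nc2c(C(=O)NCC3CCN(CCN4CCN(S(C)(=O)=O)CC4)CC3)cccc2[nH]1`: > 1.5 h (a limit)

In this assay, compound 3 gives > 1.5 h, which is a limit of the assay and not a number. It has no readable position relative to compound 1 or compound 2, since the whole set shares one reading: the limit of > 1.5 h in this assay, at which 3 of the 3 values shown sit.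

Compound 4 `COC(=O)N1CCN(CCN2CCC(CNC(=O)c3cccc4[nH]c(C(C)C)nc34)CC2)CC1` carries methoxycarbonyl in place of methylsulfonyl on an amine nitrogen in a ring, and the rest of compound 3 is unchanged: methoxycarbonyl in place of methylsulfonyl on an amine nitrogen in a ring.

For the measured compounds named here, the only measured single-place step is a step that the two limits leave unreadable from compound 1 to compound 2. That step is tert-butyl in place of cyclopropyl on an aromatic carbon, so it is a different change at a different place, and it gives no size to carry over. Going by the values given here, no measured pair covers the swap on the ring nitrogen, so the data support no direction for it. The working expectation is therefore no step beyond the scatter in this assay, with the reading staying close to the limit of compound 3.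

The expected step is a step that the limit leaves unreadable from compound 3 to compound 4.

The estimate for compound 4 is 1.7 h, with an expected range of 0.8 h to 3.5 h.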

Compound 4, half-life: > 1.5 h
Compound 4: only a limit was reported; the forecaster's own chance of this, stated with the estimate: 60%; the middle value is on the limit's open side.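

No step can be read from compound 3 to compound 4, since neither reading is a number, only a limit of the assay: the limit of > 1.5 h in this assay, at which 4 of the 4 values shown sit.

The compounds shown leave open how long the half-lives of these compounds actually are, and whether methoxycarbonyl in place of methylsulfonyl on an amine nitrogen in a ring changes the half-life at all.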